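A sulfonyl aryl swap toward compound 4

A few compounds are considered here, and "the series" means these few. Any claim that something is new, unique, unknown or untested is made for them only; others in the source may bear on it.

Measured in an in vitro assay on HEK ts201 cells for negative allosteric modulation of Neuronal acetylcholine receptor; alpha4/beta2 (Homo sapiens), read by fluorescence and calcium flux, with a stated time of 1.5 s; a lower number here means a stronger inhibitor, a higher number a weaker inhibitor:
compound 1 `O=C(CN1CCN(S(=O)(=O)c2ccc(F)cc2)CC1)Nc1ccc(F)cc1` gives 13800 nM
compound 2 `O=C(CN1CCN(S(=O)(=O)c2ccc(F)cc2)CC1)Nc1ccccc1` gives 14900 nM
compound 3 `O=C(CN1CCN(S(=O)(=O)c2cccnc2)CC1)Nc1ccccc1F` gives 20300 nM

Compound 3 holds the highest of the three numbers, though its gaps to compound 2 and to compound 1 are both within the scatter. Compound 4 `COc1ccc(S(=O)(=O)N2CCN(CC(=O)Nc3ccccc3F)CC2)cc1` differs from compound 3 by 4-methoxyphenyl in place of pyridin-3-yl on a sulfonyl sulfur. Going by the values given here, the only measured step, a 1.1-fold higher number from compound 1 to compound 2 (0.03 log units; within the scatter), concerns a hydrogen in place of fluoro on an aromatic carbon elsewhere in the molecule and lies within the scatter, so no measured step bears directly on a change at the sulfonyl sulfur. The three measured values sit close together although compound 3 carries a different aryl on that sulfur than compounds 1 and 2. Compound 4 is therefore expected to show a 1.1-fold lower number from compound 3 to compound 4 (0.05 log units; within the scatter), nothing beyond the scatter. The estimate for compound 4 in this assay is 18000 nM, between 8000 nM and 40000 nM.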

Compound 4, half-maximal inhibitory concentration: 13400 nM
Compound 4: the middle estimate sits 1.3-fold (0.13 log units) above what was measured; the range from low to high includes it.
By their numbers in this assay, from the lowest: compounds 4, 1, 2 and 3 (each within the scatter of the next).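

Going by these compounds alone, at the sulfonyl sulfur, 4-methoxyphenyl in place of pyridin-3-yl gives a 1.5-fold lower number from compound 3 to compound 4 (0.18 log units; within the scatter) in this assay, the first measured step at this position. The swap replaces a ring with one hetero atom by a carbon-only ring and adds heavy atoms, yet the step stays within the scatter. No available evidence explains this result.

From the compounds shown here alone, whether a carboxylic acid or an amine on the aryl ring would move the number beyond the scatter remains open. So does the effect of replacing the aryl on that sulfur with a cyclohexyl group.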